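The source may hold more compounds than are shown below. What is called first, only, known or untested is meant among the compounds shown, and "the series" means these compounds.

Compound 1 `Cc1ccc(OS(=O)(=O)c2ccc(N3CCN(C)C3=O)cc2)c(C)c1` is the standout of the series so far: in a functional assay on MCF7 cells (Homo sapiens) for antiproliferative activity, read by sulforhodamine B assay, with a stated time of 48 h (a higher number here means a weaker inhibitor, a lower number a stronger inhibitor), compound 1 gives 2500 nM, the lowest of the two numbers shown. Compound 3 `COc1ccc(OS(=O)(=O)c2ccc(N3CCN(C)C3=O)cc2)cc1OC` gives 12000 nM in this assay, a gap beyond the usual scatter. Compound 2 `CN1CCN(c2ccc(S(=O)(=O)Oc3cccc([N+](=O)[O-])c3)cc2)C1=O` reaches only a limit of this assay, > 100000 nM, and no number is known for it (the limit of > 100000 nM in this assay, at which 1 of the 3 values shown sits). The two numbers and the limit show that the group on the sulfonate oxygen governs the outcome. Compound 4 `CN1CCN(c2ccc(S(=O)(=O)Oc3ccc(F)cc3)cc2)C1=O` puts (4-fluorophenyl in place of 2,4-dimethylphenyl on an oxygen). The step from compound 1 to compound 4 is expected to be a modest loss of potency, a 2.4-fold higher number from compound 1 to compound 4 (0.38 log units; beyond the scatter), beyond the scatter. Compound 4 is therefore estimated at 6000 nM, in a range of 1500 nM to 25000 nM.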

Compound 4, half-maximal inhibitory concentration: > 100000 nM
Compound 4 ended at the assay's limit; the forecaster's own chance of this, stated with the estimate: 15%; middle value at least 16-fold (1.22 log units) away from the limit.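

In this assay, for the compounds shown here, the change to 4-fluorophenyl on the oxygen bonded to the sulfonyl sulfur gives the first single-place comparison, and the step is large: an at least 40-fold higher number from compound 1 to compound 4 (1.60 log units; beyond the scatter). This shows that one exchange at this position can take a compound from a measurable number to the limit. Compound 4 joins compound 2 there, and its value is a limit, not a number: the limit of > 100000 nM in this assay, at which 2 of the 4 values shown sit.

As far as these compounds go, it remains open whether the step follows from gaining the fluorine or from losing the methyl groups. From the compounds shown here alone, how an unsubstituted phenyl or a phenyl with a single methyl group would read at this position also remains open.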